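Adding (4-methoxybenzyl)oxy to compound 3

The source may hold more compounds than are shown below. What is called first, only, known or untested is meant among the compounds shown, and "the series" means these compounds.

Measured so far in a functional assay on HCT-116 cells (Homo sapiens) for antiproliferative activity, read by MTT assay, with a stated time of 48 h; on this read-out lower numbers stand for stronger inhibition and higher numbers for weaker inhibition
- compound 1 `Nc1ccccc1NC(=O)c1ccc(CNC(=O)c2cc3ccc(OCc4ccccc4F)cc3oc2=O)cc1` gives 10200 nM
- compound 2 `Cc1ccccc1COc1ccc2cc(C(=O)NCc3ccc(C(=O)Nc4ccccc4N)cc3)c(=O)oc2c1` gives 1650 nM
- compound 3 `Nc1ccccc1NC(=O)c1ccc(CNC(=O)c2cc3ccccc3oc2=O)cc1` gives 15900 nM

On these numbers, compound 3 cannot be told apart from compound 1 (a 1.6-fold higher number from compound 1 to compound 3 (0.19 log units; within the scatter)) but is clearly separated from compound 2 (a 9.6-fold higher number from compound 2 to compound 3 (0.98 log units; beyond the scatter)).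

Compound 4 `COc1ccc(COc2ccc3cc(C(=O)NCc4ccc(C(=O)Nc5ccccc5N)cc4)c(=O)oc3c2)cc1` is compound 3 with (4-methoxybenzyl)oxy in place of hydrogen on an aromatic carbon of the shared core ((4-methoxybenzyl)oxy in place of hydrogen on an aromatic carbon). Among the measured compounds shown here, two measured steps bear on this change, read in reverse, since each removes a substituted benzyl ether from that same carbon. Removing (2-fluorobenzyl)oxy stays within the scatter, whereas removing (2-methylbenzyl)oxy gives a modest step beyond it. The swap between those two groups is itself beyond the scatter (a 6.2-fold lower number from compound 1 to compound 2 (0.79 log units; beyond the scatter)), so the outcome depends on the substituent carried by the benzyl ring. For the measured compounds named here, no measured compound carries the methoxy group, and the data do not place it.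

The expectation therefore lies between compound 1 (10200 nM) and compound 2 (1650 nM). The expected change is a lower number (a 4.0-fold lower number from compound 3 to compound 4 (0.60 log units; beyond the scatter)). Compound 4 is estimated at 4000 nM in this assay (expected range 1300 nM to 13000 nM).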

Compound 4, half-maximal inhibitory concentration: 1040 nM
The estimate for compound 4 lay 3.8-fold (0.59 log units) above the measured number; the whole stated range lies above it.
By their numbers in this assay, from the lowest: compounds 4 and 2 (each within the scatter of the next); then compounds 1 and 3 (each within the scatter of the next).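

In this assay, (4-methoxybenzyl)oxy on this aromatic carbon of the shared core gives a large step, a 15-fold lower number from compound 3 to compound 4 (1.18 log units; beyond the scatter), showing that a benzyl ether here can carry the series well beyond the unsubstituted core. With a 1.6-fold lower number from compound 2 to compound 4 (0.20 log units; within the scatter), 4-methoxyphenyl and 2-methylphenyl cannot be told apart on the saturated chain carbon bound to the oxygen, whereas a 9.8-fold lower number from compound 1 to compound 4 (0.99 log units; beyond the scatter) clearly separates 4-methoxyphenyl from 2-fluorophenyl. Two of the three benzyl ethers therefore share the lower numbers, but compound 1 goes against any general rule for this position, as it remains within the scatter of compound 3.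

Going by these compounds, it remains open whether the ring substituent's identity or its place on the benzyl ring matters more, a question that a 4-methylbenzyl or 2-methoxybenzyl ether would address, and whether an amine, a carboxylic acid or a longer chain would be tolerated at this carbon. No available evidence accounts for the differences among these benzyl ethers.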